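The source may hold more compounds than are shown below. What is called first, only, known or untested is meant among the compounds shown, and "the series" means these compounds.

Measured so far in an assay on isolated protein for activation of cGMP-dependent protein kinase 1 (Homo sapiens), read by ADP-Glo, with stated times of 120 min and 40 min; a higher number here means that more compound is needed for the effect, a lower number that less compound is needed: compound 1 `Clc1cc(Cl)cc(CO[C@H]2CCCN(Cc3ccccc3)[C@H]2c2ccccc2)c1`, compound 2 `O=C(O)c1ccc(CN2CCC[C@H](O[C@H](CO)c3cc(Cl)cc(Cl)c3)[C@@H]2c2ccccc2)cc1`, compound 3 `O=C(O)c1ccc2c(CN3CCC[C@H](O[C@H](CO)c4cc(Cl)cc(Cl)c4)[C@@H]3c3ccccc3)c[nH]c2c1`.

For compound 1 the reading is only a limit, > 200000 nM. Among the compounds with values here, compound 2 gives 11000 nM in this assay, and compound 3 gives 22000 nM; the one step between them, a 2.0-fold higher number from compound 2 to compound 3 (0.30 log units; within the scatter), changes the aryl on the saturated chain carbon bound to the amine nitrogen in the ring, and it leaves the number essentially unchanged.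

Compound 4 `COc1ccc(C(=O)O)cc1CN1CCC[C@H](OCc2cc(Cl)cc(Cl)c2)[C@@H]1c1ccccc1` differs from compound 1 by 5-carboxy-2-methoxyphenyl in place of phenyl on a saturated chain carbon bound to an amine nitrogen in a ring. Within the data shown here, no measured step joins compound 1 to another compound, so the size of this change is not directly known; compounds 2 and 3, which also carry a carboxy group on that aryl, both give numbers where compound 1 gives a limit, at the limit of > 200000 nM in this assay, at which 1 of the 3 values shown sits. The step into compound 4 is therefore expected to be large and downward, an at least 6.6-fold lower number from compound 1 to compound 4 (0.82 log units; beyond the scatter), and compound 4 is estimated at 30000 nM, between 8000 nM and 150000 nM.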

Compound 4, half-maximal effective concentration: 123000 nM
For compound 4 the middle estimate is 4.1-fold (0.61 log units) below the measured one; low and high end bracket the measured number.
By their numbers in this assay, from the lowest: compounds 2 and 3 (each within the scatter of the next); then compound 4. At a limit, above all of these: compound 1.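

In this assay, within the data shown here, 5-carboxy-2-methoxyphenyl in place of phenyl on the saturated chain carbon bound to the amine nitrogen in the ring gives the first number on the core of compound 1, with an at least 1.6-fold lower number from compound 1 to compound 4 (0.21 log units; that floor lies within the scatter). That floor does not establish a change beyond the scatter. The reading for compound 1 is a limit, so only a floor can be read: the limit of > 200000 nM in this assay, at which 1 of the 4 values shown sits.

The step brings carboxy and methoxy together, so the share of each stays unresolved. From the compounds shown here alone, whether a primary amide or a tetrazole in place of the carboxy group also gives a number remains open.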